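The source may report more compounds than this note shows. Statements on the series, on what has been measured and on what is new or still open speak of the compounds shown alone.

Measured so far:
- compound 1 `Cc1cn(Cc2ccc(Cl)cc2Cl)c2c(-c3nnc(NS(=O)(=O)c4cc(F)c(F)cc4F)o3)cc(F)cc12`: 25%
- compound 2 `Cc1cn(Cc2ccc(Cl)cc2Cl)c2c(-c3nnc(NS(=O)(=O)c4ccc(Cl)c(Cl)c4)o3)cc(F)cc12`: -2%

In an assay on isolated protein with prostaglandin E2 receptor EP1 subtype (Homo sapiens) as the target, read by FLIPR, tested at 0.1 uM (on this read-out higher numbers stand for a stronger effect at the one concentration tested and lower numbers for a weaker effect), compound 1 gives 25% and compound 2 gives -2%. Compound 2 thus stands lowest of the two numbers, with compound 1 the nearest, at a gap beyond the usual scatter. The step from compound 2 to compound 3 `Cc1cn(Cc2ccc(Cl)cc2Cl)c2c(-c3nnc(NS(=O)(=O)c4ccc(F)c(F)c4)o3)cc(F)cc12` is 3,4-difluorophenyl in place of 3,4-dichlorophenyl on a sulfonyl sulfur. Within the data shown here, only one measured step bears on this change: a number 27 percentage points lower from compound 1 to compound 2 (beyond the scatter), where a ring bearing two chlorines took the place of one bearing three fluorines. Compound 3 returns to a fluorine-bearing ring, though with the two fluorines set as 3,4-difluorophenyl rather than 2,4,5-trifluorophenyl, and the step is expected to be a number 14 percentage points higher from compound 2 to compound 3 (beyond the scatter), more modest than that earlier drop. Compound 3 is therefore estimated at 12% in this assay, within a range from -8% to 32%.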

Compound 3, a percentage reported as activity, at one concentration (the size of the read-out at that concentration, not a potency): -11%
Beside the measured number, compound 3's estimate is 23 percentage points above it; the measured number lies below the stated range.
By their numbers in this assay, from the lowest: compounds 3 and 2 (each within the scatter of the next); then compound 1.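

In this assay, the change from 3,4-dichlorophenyl to 3,4-difluorophenyl on the sulfonyl sulfur gives a number 9 percentage points lower from compound 2 to compound 3 (within the scatter), so swapping these two halogens leaves the reading at this place unchanged within the usual spread of repeat measurements. Hydrogen in place of fluoro on an aromatic carbon gives a number 36 percentage points lower from compound 1 to compound 3 (beyond the scatter), which shows that fluorine on the ring is not enough by itself and that, among these three compounds, only the 2,4,5-trifluorophenyl group of compound 1 stands apart. No measurement here explains this difference.

From the compounds shown here alone, it remains open whether that single fluoro would have the same effect on a ring with other substituents. Going by these compounds, it is also open how a different group on the sulfonyl sulfur, such as a methyl group or a pyridine ring, would read in this assay.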